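Trifluoromethyl for Hydrogen on a Shared Urea Core

The compounds below may be only part of what the source reports. "The series", "measured", "known", "first", "only" and "open" are said of these compounds alone.

Measured so far:
compound 1, `N#CC1CN1C(=O)Nc1ccc([N+](=O)[O-])cc1`, 6500 nM in a functional assay on OVCAR-3 cells (Homo sapiens) for inhibition; a higher number here means a weaker inhibitor, a lower number a stronger inhibitor
compound 2, `N#CC1CN1C(=O)Nc1ccccc1`, 6800 nM in this assay

Among the measured compounds shown here, compound 2 sits with only one measured neighbour, compound 1. The step from compound 1 to compound 2, hydrogen in place of nitro on an aromatic carbon, gave a 1.0-fold higher number from compound 1 to compound 2 (0.02 log units; within the scatter), so the two compounds cannot be told apart on these numbers, and compound 2 stands together with compound 1 rather than apart from it.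

Compound 3, `N#CC1CN1C(=O)Nc1ccc(C(F)(F)F)cc1`, differs from compound 2 by trifluoromethyl in place of hydrogen on an aromatic carbon. For the measured compounds named here, the only measured step that bears on this change is the one from compound 1 to compound 2, which also swapped the group on that same aromatic carbon and produced a step within the scatter. With nothing else to draw on, no step beyond the scatter is expected in this assay for compound 3 either, in either direction, giving an expected no change at the digits printed from compound 2 to compound 3 (within the scatter).

Compound 3 is therefore estimated at 6800 nM in this assay, with a range from 3000 nM to 15000 nM.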

Compound 3, half-maximal inhibitory concentration: 5900 nM
Compound 3: the middle estimate sits 1.2-fold (0.06 log units) above what was measured; low and high end bracket the measured number.
By their numbers in this assay, from the lowest: compounds 3, 1 and 2 (each within the scatter of the next).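

In this assay, placing trifluoromethyl on this aromatic carbon gave a 1.2-fold lower number from compound 2 to compound 3 (0.06 log units; within the scatter) and exchanging nitro for it gave a 1.1-fold lower number from compound 1 to compound 3 (0.04 log units; within the scatter) so neither step separates the compounds. The earlier pair had shown only that hydrogen and nitro could not be told apart at this carbon, and trifluoromethyl now joins them as a third group, so compounds 1, 2 and 3 form a set of three that these numbers do not resolve, with no listed compound going against that reading. Nothing available explains why the three groups read alike in this assay, and the numbers alone cannot supply a reason.

The compounds shown leave open whether a different kind of group on this same carbon, such as an amine, a carboxylic acid or a longer alkyl chain, would move the number beyond the scatter. They also leave open whether the same insensitivity would hold for a group on another carbon of the aromatic ring, or for a change to the nitrile on the shared core.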